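From oxan-4-yl to pyrrolidin-1-yl on the shared core

This account rests on a few compounds, and the source may have more. Where it says the series, first, only, none or still open, it means among the compounds named here.

Of the compounds shown here, three sharing a core have been measured in a physicochemical assay for lipophilicity, at pH 7.4; a lower number here means a more polar compound, a higher number a more lipophilic compound. Compound 1 `CCc1ccc2c(c1)C=CN(C)C(=O)[C@@H]2C` gives 5.9, compound 2 `COCCOc1ccc2c(c1)C=CN(C)C(=O)[C@@H]2C` gives 4, and compound 3 `C[C@H]1C(=O)N(C)C=Cc2cc(CC3CCOCC3)ccc21` gives 5.4. Compound 3 therefore stands second highest of the three, nearer to compound 1 than to compound 2. The unmeasured compound 4 `C[C@H]1C(=O)N(C)C=Cc2cc(CN3CCCC3)ccc21` differs from it in one group: pyrrolidin-1-yl in place of oxan-4-yl on a saturated chain carbon bound to an aromatic carbon.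

The closest measured step is a number 0.50 log units lower from compound 1 to compound 3 (beyond the scatter), a modest change at that same place, where oxan-4-yl replaced methyl. Two further steps, a number 1.90 log units lower from compound 1 to compound 2 (beyond the scatter) and a number 1.40 log units higher from compound 2 to compound 3 (beyond the scatter), are both large and show how far a change of group on the aromatic carbon can move the number in this small set. For the measured compounds named here, no measured compound carries a ring nitrogen, so none of these steps serves as a direct precedent, and the expectation is correspondingly loose. The expected change is a large fall, estimated as a number 1.40 log units lower from compound 3 to compound 4 (beyond the scatter). Compound 4 is thus expected at 4, with an estimated range from 3.2 to 4.8.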

Compound 4, distribution coefficient: 1.5
Compound 4: the middle estimate sits 2.50 log units above what was measured, and the stated range ends above it.
By their numbers in this assay, from the lowest: compound 4; then compound 2; then compound 3; then compound 1.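

At the saturated chain carbon bound to an aromatic carbon, pyrrolidin-1-yl in place of oxan-4-yl gives a number 3.90 log units lower from compound 3 to compound 4 (beyond the scatter) in this assay, even though each group is one non-aromatic ring with 1 hetero atom, 0 hydrogen-bond donors and 1 hydrogen-bond acceptor. The same position had given only a number 0.50 log units lower from compound 1 to compound 3 (beyond the scatter) when oxan-4-yl replaced methyl, so the group placed here can move the number far more than that modest step suggested, as a number 4.40 log units lower from compound 1 to compound 4 (beyond the scatter) also shows, and the change to (pyrrolidin-1-yl)methyl on the aromatic carbon places compound 4 under the most polar earlier compound, with a number 2.50 log units lower from compound 2 to compound 4 (beyond the scatter). No supporting evidence is available to explain the size of this fall.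

With only one compound carrying a ring nitrogen, the compounds shown leave open whether the fall belongs to pyrrolidin-1-yl itself or would also appear with another amine at this place, such as piperidin-1-yl, morpholin-4-yl or dimethylamino. Nor do they tell whether a longer chain carrying the pyrrolidine ring, or a carboxylic acid at this place, would move the number as far.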